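Removing One Fluorine from Compound 2

The compounds below may be only part of what the source reports. "The series", "measured", "known", "first", "only" and "open" are said of these compounds alone.

Of the compounds shown here, three with a shared core have been tested in a functional assay on CCRF-CEM cells (Homo sapiens) for cytotoxicity, in the absence of a further agent; a higher number here means a weaker inhibitor, a lower number a stronger inhibitor. Compound 2 `Nc1nc(N)c(CCCNc2cc(F)c(F)cc2[N+](=O)[O-])c(O)n1` gives 97000 nM. Compound 3 `COC(=O)c1ccc(CN(CCCc2c(N)nc(N)nc2O)c2cc(F)c(F)cc2[N+](=O)[O-])cc1` gives 59000 nM, and the step of a 1.6-fold lower number from compound 2 to compound 3 (0.22 log units; within the scatter) stays within the scatter. Compound 1 `Nc1nc(N)c(CCCN(Cc2ccc(NC(CCC(=O)O)C(=O)O)cc2)c2cc(F)cc(F)c2[N+](=O)[O-])c(O)n1` reaches only a limit of the assay, > 100000 nM; this is the one case noted as the limit of > 100000 nM in this assay, at which 1 of the 3 values shown sits. Among the two actual numbers, compound 2 stands highest, with compound 3 nearest at a gap that is within the scatter.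

The unmeasured compound 4 `Nc1nc(N)c(CCCNc2cc(F)ccc2[N+](=O)[O-])c(O)n1` differs from compound 2 by hydrogen in place of fluoro on an aromatic carbon. Among the compounds with values here, no measured step touches a fluoro group: the only single-point step, from compound 2 to compound 3, adds a 4-(methoxycarbonyl)benzyl on a nitrogen and is itself within the scatter. There is therefore nothing to point toward a change in either direction, and the expectation is no step beyond the scatter, so that the estimated change is a 1.0-fold higher number from compound 2 to compound 4 (0.01 log units; within the scatter). For compound 4 the estimate is 100000 nM, expected to lie between 40000 nM and 250000 nM.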

Compound 4, half-maximal inhibitory concentration: > 100000 nM
Compound 4 gave a limit, no number; the forecaster's own chance of this, stated with the estimate: 45%; the middle value lies on the limit itself.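

Within the data shown here, replacing fluoro with hydrogen on the aromatic carbon ortho to a fluoro group is the first change here that touches a fluorine on the ring, and it gives an at least 1.0-fold higher number from compound 2 to compound 4 (0.01 log units; that floor lies within the scatter). In this assay, among these compounds, losing this one fluorine therefore brings no sign of a stronger inhibitor, something the earlier compounds, which offered no single change at this carbon, could not show. The result for compound 4 is a limit, not a number, and one other compound shown shares it: the limit of > 100000 nM in this assay, at which 2 of the 4 values shown sit.

From the compounds shown here alone, how far compound 4 really lies from compound 2 stays open, so it is unclear whether this fluoro group matters much or hardly at all. Also open, going by these compounds, is what a chlorine, an amine or a methoxy group on this same carbon would do.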